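This account rests on a few compounds, and the source may have more. Where it says the series, first, only, none or still open, it means among the compounds named here.

Measured so far:
compound 1 `COc1cc(-c2cc(/C=C/C(=O)c3ccc(Cl)c(Cl)c3)[nH]n2)cc(OC)c1OC` — 62500 nM
compound 2 `COc1ccc(-c2cc(/C=C/C(=O)c3ccc(N)cc3)[nH]n2)cc1` — 63600 nM

Both were run in a functional assay on SK-OV-3 cells (Homo sapiens) for inhibition, read by sulforhodamine B assay, with a stated time of 48 h; on this read-out lower numbers stand for higher toxicity in this test and higher numbers for lower toxicity in this test. Compound 1 gives 62500 nM, and compound 2 gives 63600 nM; the two numbers lie within the scatter of each other, so neither is set apart. Within the data shown here, no step between measured compounds is available. Compound 3 `COc1ccc(C(=O)/C=C/c2cc(-c3cc(OC)c(OC)c(OC)c3)n[nH]2)cc1OC` is the next candidate; it differs from compound 1 by 3,4-dimethoxyphenyl in place of 3,4-dichlorophenyl on a carbonyl carbon. Among the measured compounds shown here, with no comparable step on record, no change beyond the scatter is expected here, and the step of a 1.0-fold higher number from compound 1 to compound 3 (0.02 log units; within the scatter) is expected to be small in either direction. Compound 3 is estimated at 65000 nM, within 25000 nM to 170000 nM.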

Compound 3, concentration lethal to 50% of the cells: 27600 nM
The estimate for compound 3 lay 2.4-fold (0.37 log units) above the measured number; measured number inside the range.
By their numbers in this assay, from the lowest: compound 3; then compounds 1 and 2 (each within the scatter of the next).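

Replacing 3,4-dichlorophenyl with 3,4-dimethoxyphenyl on a carbonyl carbon gives a 2.3-fold lower number from compound 1 to compound 3 (0.35 log units; beyond the scatter) in this assay, so the number at this position does depend on the group it carries. The entering group has 2 hydrogen-bond acceptors and the leaving group 0, but a single step cannot separate that difference from the exchange of chlorine for oxygen. Nothing on record explains the step. As far as these compounds go, whether a nitrile or a carboxylic acid on this phenyl ring would shift the number remains open. So does whether the same step holds on the core of compound 2.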